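This account rests on a few compounds, and the source may have more. Where it says the series, first, only, none or still open, it means among the compounds named here.

Measured so far:
Compound 1 `COc1cccc(CNCCCNc2ccnc3cc(-c4ccccc4)ccc23)c1O`: in a physicochemical assay for acid dissociation, compound 1 gives 9.47.
Compound 2 `COc1ccc(F)cc1CNCCCNc1ccnc2cc(CCc3ccccc3)ccc12`: in this assay compound 2 gives 9.47.
Compound 3 `COc1cccc(CNCCCNc2ccnc3cc(CCc4ccccc4)ccc23)c1O`: in this assay compound 3 gives 9.47.

Compound 4 `COc1ccc(F)cc1CNCCCNc1ccnc2cc(-c3ccccc3)ccc12` has not yet been measured. It stands to compound 2 as compound 1 stands to compound 3: the change is phenyl in place of phenethyl on an aromatic carbon, and from compound 3 to compound 1 it is phenyl in place of phenethyl on an aromatic carbon. The place lines agree word for word, so this is the same change. Measured, it gave no change at the digits printed from compound 3 to compound 1 (within the scatter). The two cores differ by 5-fluoro-2-methoxyphenyl in place of 2-hydroxy-3-methoxyphenyl on a saturated chain carbon bound to an amine nitrogen; that step gave no change at the digits printed from compound 2 to compound 3 (within the scatter), so all three values lie together within the scatter. The step from compound 2 to compound 4 in this assay is expected to be no change at the digits printed from compound 2 to compound 4 (within the scatter) because no change at the digits printed from compound 3 to compound 1 (within the scatter) showed no movement for the same change. For compound 4 the estimate is 9.47, with a range from 9.2 to 9.75.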

Compound 4, acid dissociation constant: 9.47
Beside the measured number, compound 4's estimate shows no gap at the digits printed, and the stated range covers the measured number.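

In this assay, phenyl in place of phenethyl on an aromatic carbon gives no change at the digits printed from compound 2 to compound 4 (within the scatter) and, on the other core, no change at the digits printed from compound 3 to compound 1 (within the scatter); the same replacement therefore carries between these two cores with no movement outside the scatter, and the aryl exchange gives no change at the digits printed from compound 1 to compound 4 (within the scatter) on the phenyl-bearing core. Among the compounds shown here, with all four compounds level, this shows only that neither change moves this read-out here; it does not show that the phenyl change would behave alike on any further core or in any other read-out. Nothing at hand bears on why the values stay level.

Still open, on these data alone, is whether an amine or a carboxylic acid on that aromatic carbon would leave this assay level. Also open, as far as these compounds go, is whether a longer chain in place of phenethyl would do the same.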